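Nitro to amino on compound 3

A few compounds are considered here, and "the series" means these few. Any claim that something is new, unique, unknown or untested is made for them only; others in the source may bear on it.

Of the compounds shown here, three have been read in a functional assay on A549 cells (Homo sapiens) for inhibition (on this read-out lower numbers stand for stronger inhibition and higher numbers for weaker inhibition), and none gives a number. Compound 1 `FC(F)(F)c1ccc(/C=C\c2ccc3ccccc3c2)cc1` reports > 5000 nM, which is a limit. Compound 2 `COc1ccc(/C=C/c2ccc3ccccc3c2)cc1[N+](=O)[O-]` reports > 5000 nM, also a limit. Compound 3 `COc1ccc(/C=C\c2ccc3ccccc3c2)cc1[N+](=O)[O-]` reports > 20000 nM, again a limit. Among the compounds with values here, compound 3 therefore has no readable potency on the numbers so far.

The next structure is compound 4 `COc1ccc(/C=C\c2ccc3ccccc3c2)cc1N`, with the change (amino in place of nitro on an aromatic carbon). In words, this is amino in place of nitro on an aromatic carbon, ortho to a methoxy group.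

Within the data shown here, the one measured step is a step that the two limits leave unreadable from compound 2 to compound 3, and it offers no size to borrow. It is also a change of another kind, as shown by the fact that compounds 2 and 3 differ only in the configuration as drawn, and the nitro group stays in place across it. Among the measured compounds shown here, no measured step replaces the nitro group, so the expected size is only loosely bounded. The expectation rests on compound 3 alone, whose > 20000 nM is a limit: a readable number for compound 4 would lie on the side of stronger inhibition. Another limit also remains possible. The expected change, estimated with wide uncertainty, is an at least 6.6-fold lower number from compound 3 to compound 4 (0.82 log units; beyond the scatter). For compound 4 the estimate is 3000 nM, with an expected range from 300 nM to 20000 nM.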

Compound 4, half-maximal inhibitory concentration: > 20000 nM
Compound 4: a limit, no number (the forecaster's own chance of this, stated with the estimate: 35%); middle value at least 6.6-fold (0.82 log units) from the limit.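

The step from compound 3 to compound 4 cannot be read, since both compounds stand only as limits, and at the same limit, in this assay: the limit of > 20000 nM in this assay, at which 2 of the 4 values shown sit.

Whether amino in place of nitro changes inhibition at all stays open, as does whether any compound shown has a readable potency in this assay.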